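Swapping the aryl on the carbonyl: methoxy to difluoro

The source may hold more compounds than are shown below. What is called first, only, known or untested is meant among the compounds shown, and "the series" means these compounds.

Measured compounds:
- compound 1, `COc1cc(-c2cc(/C=C/C(=O)c3ccc(Cl)c(Cl)c3)[nH]n2)cc(OC)c1OC`: -16%
- compound 2, `COc1ccc(C(=O)/C=C/c2cc(-c3cc(OC)c(OC)c(OC)c3)n[nH]2)cc1`: -87%

Among the compounds with values here, in a functional assay on SK-MEL-28 cells (Homo sapiens) for cytotoxicity, read by sulforhodamine B assay, with a stated time of 48 h, tested at 100 uM (on this read-out higher numbers stand for a weaker effect at the one concentration tested and lower numbers for a stronger effect), compound 2 gives -87%, the lower of the two numbers and therefore the stronger effect at the single concentration; the only measured neighbour, compound 1, sits higher beyond the scatter. Compound 3, `COc1cc(-c2cc(/C=C/C(=O)c3ccc(F)c(F)c3)[nH]n2)cc(OC)c1OC`, is not yet measured. It differs from compound 2 in one place: 3,4-difluorophenyl in place of 4-methoxyphenyl on a carbonyl carbon.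

Within the data shown here, one measured step bears on this. Going from the 3,4-dichlorophenyl of compound 1 to the 4-methoxyphenyl of compound 2, the read-out moved by a number 71 percentage points lower from compound 1 to compound 2 (beyond the scatter). Compound 3 reverses that direction, giving up the 4-methoxyphenyl for a 3,4-difluorophenyl, a group more like the 3,4-dichlorophenyl of compound 1 than like the 4-methoxyphenyl. A step back upward in this assay, beyond the scatter but not necessarily all the way to compound 1, is therefore expected: a number 52 percentage points higher from compound 2 to compound 3 (beyond the scatter). Compound 3 is estimated at -35%, within -80% to 5%.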

Compound 3, a percentage reported as activity, at one concentration (the size of the read-out at that concentration, not a potency): -39%
The estimate for compound 3 lay 4 percentage points above the measured number; the measured number falls inside the stated range.
By their numbers in this assay, from the lowest: compound 2; then compound 3; then compound 1.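

In this assay the 3,4-difluorophenyl on the carbonyl carbon lands in the middle of the order: the read-out shows a number 48 percentage points higher from compound 2 to compound 3 (beyond the scatter) and also a number 23 percentage points lower from compound 1 to compound 3 (beyond the scatter) when the comparison is made with the dichloro group. This position therefore does more than separate the 4-methoxyphenyl from the two halogen-bearing groups, since exchanging chlorine for fluorine at the same ring positions also moves the number beyond the scatter. Nothing available explains why the three groups fall in this order.

The three compounds leave open whether the low number of compound 2 depends on the methoxy group itself, which a 4-hydroxyphenyl or an unsubstituted phenyl on the carbonyl carbon would help to test. They also leave open how a 4-fluorophenyl, with a single fluorine, would compare with the 3,4-difluorophenyl.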